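Hydrazone aryl swap on a triazolyl thioether core

The compounds below may be only part of what the source reports. "The series", "measured", "known", "first", "only" and "open" are said of these compounds alone.

Compound 1, `Fc1cccc(F)c1CSc1nnc(-c2ccncc2)n1-c1ccccc1` — in a functional assay on MCF7 cells (Homo sapiens) for inhibition, read by MTT assay, with a stated time of 48 h (on this read-out lower numbers stand for stronger inhibition and higher numbers for weaker inhibition), compound 1 gives > 50000 nM, which is a limit of the assay and not a number.
Compound 2, `O=C(CSc1nnc(-c2ccncc2)n1-c1ccccc1)N/N=C/c1ccc([N+](=O)[O-])cc1` — in this assay compound 2 gives 15300 nM.

Among the compounds with values here, compound 2 is the only compound of the pair for which this assay returns a number; the other entry, for compound 1, sits at a limit (the limit of > 50000 nM in this assay, at which 1 of the 2 values shown sits). Compound 2 therefore stands alone as the reference point for anything that follows.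

Compound 3, `O=C(CSc1nnc(-c2ccncc2)n1-c1ccccc1)N/N=C/c1cc(Br)ccc1O`, has not yet been tested. It differs from compound 2 in one place: 5-bromo-2-hydroxyphenyl in place of 4-nitrophenyl on a carbon with a double bond to nitrogen. The two aryl groups differ in their counted atoms, donors and acceptors as described there, and nothing more can be said of the change from the data shown.

Within the data shown here, no step between two measured compounds is available, so there is no precedent to lean on. Compound 3 is expected to stay close to compound 2, the estimated step being a 1.3-fold lower number from compound 2 to compound 3 (0.11 log units; within the scatter), with no movement beyond the usual scatter. On that basis compound 3 is estimated at 12000 nM in this assay, within a range from 3500 nM to 45000 nM.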

Compound 3, half-maximal inhibitory concentration: 6460 nM
The estimate for compound 3 lay 1.9-fold (0.27 log units) above the measured number, and the stated range covers the measured number.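

Within the data shown here, compound 2 had offered only a single number, and the new result shows that this position, the carbon with a double bond to nitrogen, responds to a change of aryl group: putting 5-bromo-2-hydroxyphenyl in place of 4-nitrophenyl gives a 2.4-fold lower number from compound 2 to compound 3 (0.37 log units; beyond the scatter) in this assay. Among these compounds, the step is modest, but it is the first that can be read, and it shows that the 4-nitrophenyl group is not needed for a measurable number in this read-out. The entering group brings a bromine and a hydrogen-bond donor that the leaving group lacks, yet nothing measured here bears on why the number moved.

The compounds shown leave open whether the step belongs to the bromine, to the hydroxyl or to the two together, which a phenyl group carrying only one of them would separate. Also open, going by these compounds, is how an amine or a carboxylic acid on this aryl ring would read in this assay, and whether any such group would take the number lower than that of compound 3, at 6460 nM.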